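Stripping the hydroxyphenyl from a triazole-bearing lactone

The source may report more compounds than this note shows. Statements on the series, on what has been measured and on what is new or still open speak of the compounds shown alone.

Two close relatives open this series. Compound 1 `O=C1O[C@H]([C@@H](O)Cn2cc(-c3cccc(O)c3)nn2)C(OCc2ccccc2)=C1OCc1ccccc1` carries a hydroxyl beside the triazole, while compound 2 `O=C1O/C(=C\Cn2cc(-c3cccc(O)c3)nn2)C(OCc2ccccc2)=C1OCc1ccccc1` has a double bond in that position; the rest of the two molecules is the same. Both were tested in a functional assay on A549 cells (Homo sapiens) for antiproliferative activity, read by MTT assay, with a stated time of 72 h; a lower number here means a stronger inhibitor, a higher number a weaker inhibitor. Compound 1 gives 59900 nM and compound 2 gives 23300 nM, so compound 1 has the higher of the two numbers and is the weaker inhibitor, and the gap between the two lies beyond the usual scatter.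

Compound 3 `O=C1O[C@H]([C@@H](O)Cn2ccnn2)C(OCc2ccccc2)=C1OCc1ccccc1` is compound 1 with one change: hydrogen in place of 3-hydroxyphenyl on an aromatic carbon. Within the data shown here, no measured pair in this set shows such a change, so its effect must be estimated. The change removes a whole aromatic ring together with its hydrogen-bond donor and acceptor, and compound 1 is already the weakest of the measured pair at 59900 nM. The step from compound 1 to compound 3 is expected to be a 1.6-fold higher number from compound 1 to compound 3 (0.20 log units; within the scatter), towards a higher number and a weaker inhibitor, with a real chance that only a limit is reported. Compound 3 is estimated at 95000 nM, most likely between 40000 nM and 220000 nM.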

Compound 3, half-maximal inhibitory concentration: > 100000 nM
Compound 3 was reported as a limit; the forecaster's own chance of this, stated with the estimate: 35%; at least 1.0-fold (0.02 log units) between middle value and limit.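

In this assay compound 3 is reported only as a limit: the limit of > 100000 nM in this assay, at which 1 of the 3 values shown sits. As far as these compounds go, replacing the 3-hydroxyphenyl on the triazole with hydrogen therefore gives only a floor, an at least 1.6-fold higher number from compound 1 to compound 3 (0.22 log units; that floor lies within the scatter), and the true size of the step stays unknown; it could be small or much larger. Among these compounds, this is the first look at this position, as the earlier pair differed only at the link to the triazole, and the one thing the result fixes is that removing the group yields no measurable gain in strength in this assay.

From the compounds shown here alone, what remains open is whether any effect of this change comes from the aromatic ring or from its hydroxyl, a question that a plain phenyl or a 3-methoxyphenyl at this carbon would address. Going by these compounds, it is also open whether the same replacement on compound 2, the partner with the double bond, would behave in the same way, and whether a small group such as methyl or an amine would differ from hydrogen here.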